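Two Halogen Pairs Traded on the Aryl Arm

This account rests on a few compounds, and the source may have more. Where it says the series, first, only, none or still open, it means among the compounds named here.

Measured so far:
Compound 1, `CCOC(=O)c1ccc(NC(=O)CSc2snnc2-c2ccc(Cl)cc2Cl)c(Br)c1`: > 228000 nM
Compound 2, `O=C(CSc1snnc1-c1ccc(F)cc1F)Nc1ccccc1Br`: 144000 nM

Both were run in an ADME assay on MT4 cells (Homo sapiens) for cytotoxicity; a lower number here means that less compound is tolerated, a higher number that more compound is tolerated. For compound 1 the figure > 228000 nM is a limit of the assay, not a number. For the measured compounds named here, compound 2 gives 144000 nM, the only real number on hand. The entry for compound 1 is a limit, as summarised by the limit of > 228000 nM in this assay, at which 1 of the 2 values shown sits. Going by the values given here, no pair of measured compounds differs in a single place, so no measured step exists to lean on.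

Compound 3, `O=C(CSc1snnc1-c1ccc(Cl)cc1Cl)Nc1ccccc1Br`, is not yet measured. It differs from compound 2 by 2,4-dichlorophenyl in place of 2,4-difluorophenyl on an aromatic carbon, in words: 2,4-dichlorophenyl in place of 2,4-difluorophenyl on an aromatic carbon. Among the compounds with values here, with no comparable step in the data, the expectation rests only on the size of the change, which is small and keeps the same pattern of substitution. The step from compound 2 to compound 3 is expected to be modest, a 1.4-fold lower number from compound 2 to compound 3 (0.16 log units; within the scatter), and could sit within the scatter, with a slight lean toward less compound being tolerated. Compound 3 is therefore estimated at 100000 nM, in the range 40000 nM to 250000 nM.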

Compound 3, half-maximal cytotoxic concentration: >= 146000 nM
Compound 3 gave a limit, no number (the forecaster's own chance of this, stated with the estimate: 20%); at least 1.4-fold (0.16 log units) between middle value and limit.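

In this assay the entry for compound 3 is a limit of the assay and not a number: the limit of >= 146000 nM in this assay, at which 1 of the 3 values shown sits.

Going by these compounds, on this aromatic carbon of the five-membered ring, 2,4-dichlorophenyl can take the place of 2,4-difluorophenyl with no readable fall in the amount of compound tolerated (an at least 1.0-fold higher number from compound 2 to compound 3 (0.00 log units; that floor lies within the scatter)), and the true size of the step stays unknown, since only its floor is given. The step between compound 1 and compound 3, hydrogen in place of ethoxycarbonyl on an aromatic carbon, cannot be read, as both entries are limits.

On these data alone, what remains open is where the real value of compound 3 lies, and so whether the swap of the two halogen pairs changes the tolerated amount at all. Also open, as far as these compounds go, is how this assay would respond to other groups on the shared core, such as a plain phenyl or a 2,4-dimethoxyphenyl on the same carbon, or a carboxylic acid where compound 1 carries its ethoxycarbonyl.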